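Thiazolyl in Place of the Amide Arm: Cytotoxicity Outlook

The source may hold more compounds than are shown below. What is called first, only, known or untested is meant among the compounds shown, and "the series" means these compounds.

Measured compounds:
compound 1, `CN(C(=O)CN1CCN(c2nc(=O)c3cc(C(F)(F)F)cc([N+](=O)[O-])c3s2)CC1)c1ccccc1`: > 10000 nM
compound 2, `COC(=O)[C@@H]1OC2(CCN(c3nc(=O)c4cc(C(F)(F)F)cc([N+](=O)[O-])c4s3)CC2)O[C@H]1c1ccccc1`: > 10000 nM
compound 3, `COC(=O)C1CN(c2nc(=O)c3cc(C(F)(F)F)cc([N+](=O)[O-])c3s2)CCC12OC[C@H](C)O2`: > 10000 nM

In an ADME assay on HEK293 cells (Homo sapiens) for cytotoxicity, read by MTT assay, with a stated time of 24 h (on this read-out higher numbers stand for lower toxicity in this test and lower numbers for higher toxicity in this test), compound 1 gives > 10000 nM, which is a limit of the assay rather than a number. Compound 2 likewise reaches only a limit, > 10000 nM. Compound 3 also sits at a limit, > 10000 nM. Compound 1 therefore stands where all of its companions stand, namely at the limit of > 10000 nM in this assay, at which 3 of the 3 values shown sit, and nothing in the three results sets any of them apart from the others. Going by the values given here, no pair among the measured compounds differs in a single place, so no measured step exists from which the effect of a change could be read.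

Compound 4, `O=c1nc(N2CCN(c3nccs3)CC2)sc2c([N+](=O)[O-])cc(C(F)(F)F)cc12`, is the untested member. Relative to compound 1 the change is 1,3-thiazol-2-yl in place of (methyl(phenyl)carbamoyl)methyl on an amine nitrogen in a ring. With every measured value resting at the limit of > 10000 nM in this assay, at which 3 of the 3 values shown sit, the expectation for compound 4 is that it too will not cross that limit; the step that the limit leaves unreadable from compound 1 to compound 4 is expected to be none beyond the scatter. Compound 4 is estimated at 15000 nM in this assay, with a plausible range from 6000 nM to 50000 nM, and a reported limit is the most likely outcome.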

Compound 4, half-maximal cytotoxic concentration: > 10000 nM
Compound 4: no number, only a limit; the forecaster's own chance of this, stated with the estimate: 75%; the middle value is on the limit's open side.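

In this assay compound 4 gives > 10000 nM, which is a limit and not a number. Going by these compounds alone, compound 1 also rests at a limit, so no step between compound 1 and compound 4 can be read. The compounds shown leave open whether 1,3-thiazol-2-yl in place of (methyl(phenyl)carbamoyl)methyl changes the read-out at all, and how the four compounds compare: the limit of > 10000 nM in this assay, at which 4 of the 4 values shown sit.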